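The source may report more compounds than this note shows. Statements on the series, on what has been measured and on what is new or still open speak of the compounds shown alone.

The three measured compounds share one core. Compound 1 is `CNC(=O)c1cc(C(=O)NC2CC2)cn(Cc2ccc3nc[nH]c3c2)c1=O`, compound 2 is `CNC(=O)c1cc(C(=O)NC2CC2)cn(Cc2cccc3cc[nH]c23)c1=O` and compound 3 is `CNC(=O)c1cc(C(=O)NC2CC2)cn(Cc2cccc([C@@H](C)O)c2)c1=O`. In a physicochemical assay for solubility (a higher number here means a more soluble compound, a lower number a less soluble compound), compound 3 gives >= 131 ug/mL, which is a limit of the assay and not a number. In this assay compound 1 gives >= 163 ug/mL, likewise a limit. Compound 2 gives >= 144 ug/mL, again a limit. Compound 3 therefore stands on a limit among limits: the limit of >= 131 ug/mL in this assay, at which 1 of the 3 values shown sits, the limit of >= 144 ug/mL in this assay, at which 1 of the 3 values shown sits, and the limit of >= 163 ug/mL in this assay, at which 1 of the 3 values shown sits, each hold one value, and no order among the three can be read.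

Compound 4 is `CNC(=O)c1cc(C(=O)NC2CC2)cn(Cc2nccc3[nH]ccc23)c1=O`. The change from compound 3 is a group of 9 heavy atoms (7 carbon, 2 nitrogen; one five-membered aromatic ring with 1 hetero atom, one six-membered aromatic ring with 1 hetero atom) in place of a group of 9 heavy atoms (8 carbon, 1 oxygen; one six-membered aromatic ring of carbon only), on a saturated chain carbon bound to an aromatic nitrogen. Within the data shown here, the steps that bear on it are a step that the two limits leave unreadable from compound 1 to compound 3, a step that the two limits leave unreadable from compound 2 to compound 3 and a step that the two limits leave unreadable from compound 1 to compound 2; none of them has a readable size, since every value involved is a limit. No step beyond the scatter is therefore expected in this assay, and a further limit is the likelier outcome. Compound 4 is expected to give 150 ug/mL, within 60 ug/mL to 400 ug/mL. The step that the limit leaves unreadable from compound 3 to compound 4 is the expected consequence.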

Compound 4, solubility: 73 ug/mL
For compound 4 the middle estimate is 2.1-fold (0.31 log units) above the measured one, within the range that was stated.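

In this assay, among these compounds, compound 4 gives 73 ug/mL, the first value that is a number and not a limit, so a change of group on a saturated chain carbon bound to an aromatic nitrogen can be read here. The clearest result is an at least 2.2-fold lower number from compound 1 to compound 4 (0.34 log units; beyond the scatter), while the other two floors are an at least 1.9-fold lower number from compound 2 to compound 4 (0.29 log units; that floor lies within the scatter) and an at least 1.7-fold lower number from compound 3 to compound 4 (0.25 log units; that floor lies within the scatter). The value of compound 1 is itself a limit, so that step gives only a floor: the limit of >= 163 ug/mL in this assay, at which 1 of the 4 values shown sits.

The steps among compound 1, compound 2 and compound 3 cannot be read, which leaves their order open. Also open, going by these compounds, are the true sizes of the three steps to compound 4 and how this assay would read with an amine or a carboxylic acid on the group at this place.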